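Acrylamide terminus variation on a shared quinazoline-free core series

This account rests on a few compounds, and the source may have more. Where it says the series, first, only, none or still open, it means among the compounds named here.

Compound 1 `C=C(C)C(=O)Nc1cc2c(N3CCc4ccccc43)ncnc2cc1OC`, tested in a functional assay on MCF7 cells (Homo sapiens) for antiproliferative activity, read by MTT assay, with a stated time of 72 h (a higher number here means a weaker inhibitor, a lower number a stronger inhibitor), gives 11100 nM.
Compound 2 `CCC/C=C/C(=O)Nc1cc2c(N3CCc4ccccc43)ncnc2cc1OC` gives 3160 nM in this assay.
Compound 3 `CCN(CC)C/C=C/C(=O)Nc1cc2c(N3CCc4ccccc43)ncnc2cc1OC` gives 1990 nM in this assay.

Compound 3 carries the lowest of the three numbers, though it sits only a 1.6-fold lower number from compound 2 to compound 3 (0.20 log units; within the scatter), within the scatter, while it stands clearly apart from compound 1, a 5.6-fold lower number from compound 1 to compound 3 (0.75 log units; beyond the scatter). Compound 4 `COc1cc2ncnc(N3CCc4ccccc43)c2cc1NC(=O)/C=C/CN1CCN(C)CC1` differs from compound 3 in one place: 4-methylpiperazin-1-yl in place of diethylamino on a saturated chain carbon bound to a double-bonded chain carbon. Of the measured steps, only the move from compound 2 to compound 3 touches the same site, and it was small: a 1.6-fold lower number from compound 2 to compound 3 (0.20 log units; within the scatter). For the measured compounds named here, no measured step exchanges one amine for another at this carbon, so there is no direct precedent for the size of the change. The expectation in this assay is therefore a step of a 1.0-fold higher number from compound 3 to compound 4 (0.00 log units; within the scatter), that is, none beyond the scatter. Compound 4 is estimated at 2000 nM, with a range from 800 nM to 5000 nM.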

Compound 4, half-maximal inhibitory concentration: 6430 nM
The estimate for compound 4 lay 3.2-fold (0.51 log units) below the measured number, and the stated range ends below it.
By their numbers in this assay, from the lowest: compounds 3 and 2 (each within the scatter of the next); then compounds 4 and 1 (each within the scatter of the next).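

In this assay, for the compounds shown here, the identity of the amine on this saturated chain carbon proves to matter: the first exchange of one amine for another gives a 3.2-fold higher number from compound 3 to compound 4 (0.51 log units; beyond the scatter) and moves beyond the scatter. Diethylamino in place of ethyl had stayed within the scatter, whereas 4-methylpiperazin-1-yl in place of ethyl gives a 2.0-fold higher number from compound 2 to compound 4 (0.31 log units; beyond the scatter) and does not. The full 3-(4-methylpiperazin-1-yl)prop-1-en-1-yl group in place of 1-methylethenyl gives only a 1.7-fold lower number from compound 1 to compound 4 (0.24 log units; within the scatter) and so lacks the clear separation from compound 1 that the diethylamino chain showed.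

The compounds shown leave open whether a morpholine, a pyrrolidine or dimethylamino at this carbon would read like diethylamino or like 4-methylpiperazin-1-yl. They also leave open whether a piperazine without the methyl group would read the same way. No evidence is available that bears on this difference between the two amines.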